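The compounds below may be only part of what the source reports. "The series", "measured", "known", "first", "only" and "open" are said of these compounds alone.

Working notes on the series, all read in a functional assay on MDA-MB-231 cells (Homo sapiens) for antiproliferative activity, read by MTT assay, with a stated time of 72 h; a lower number here means a stronger inhibitor, a higher number a weaker inhibitor. Compound 1 (`CC1=CC[C@H]2[C@H](CC[C@]2(C)O)C(C)(C)[C@@H]1CC[C@H]1[C@]2(C)CC[C@H](OC(=O)c3ccc([N+](=O)[O-])cc3)C(C)(C)O[C@H]2CC[C@@]1(C)O`) gives 8900 nM, compound 2 (`CC1=CC[C@H]2[C@H](CC[C@]2(C)O)C(C)(C)[C@@H]1CC[C@H]1[C@]2(C)CC[C@H](OC(=O)c3ccccc3C(F)(F)F)C(C)(C)O[C@H]2CC[C@@]1(C)O`) gives 31500 nM, and compound 3 (`CC1=CC[C@H]2[C@H](CC[C@]2(C)O)C(C)(C)[C@@H]1CC[C@H]1[C@]2(C)CC[C@H](OC(=O)c3ccc(C(F)(F)F)c(F)c3)C(C)(C)O[C@H]2CC[C@@]1(C)O`) gives 22200 nM. Compound 3 cannot be separated from its nearest neighbour: a 1.4-fold lower number from compound 2 to compound 3 (0.15 log units; within the scatter). The two trifluoromethyl-bearing compounds both lie on the high side of the 4-nitrophenyl one, with modest steps: a 3.5-fold higher number from compound 1 to compound 2 (0.55 log units; beyond the scatter) and a 2.5-fold higher number from compound 1 to compound 3 (0.40 log units; beyond the scatter).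

The next change leads to compound 4 (`CC1=CC[C@H]2[C@H](CC[C@]2(C)O)C(C)(C)[C@@H]1CC[C@H]1[C@]2(C)CC[C@H](OC(=O)c3ccc([N+](=O)[O-])o3)C(C)(C)O[C@H]2CC[C@@]1(C)O`): 5-nitrofuran-2-yl in place of 3-fluoro-4-(trifluoromethyl)phenyl on a carbonyl carbon. Among the compounds with values here, no furan has been measured, so the only guide is the nitro group, carried so far by one compound. Read in reverse, a 2.5-fold higher number from compound 1 to compound 3 (0.40 log units; beyond the scatter) is the closest precedent, and it suggests a modest step to a lower number in this assay, probably not the whole distance. The expected change is a 2.1-fold lower number from compound 3 to compound 4 (0.33 log units; beyond the scatter). For compound 4 the estimated value is 10500 nM, with an expected range from 4500 nM to 24000 nM.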

Compound 4, half-maximal inhibitory concentration: 11100 nM
Compound 4: middle estimate off by 1.1-fold (0.02 log units), on the low side, within the range that was stated.
By their numbers in this assay, from the lowest: compounds 1, 4, 3 and 2 (each within the scatter of the next, the first and the last beyond it).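

The 5-nitrofuran-2-yl group on this carbonyl carbon cannot be separated from 4-nitrophenyl (a 1.2-fold higher number from compound 1 to compound 4 (0.10 log units; within the scatter)), so at this position a five-membered aromatic ring with one hetero atom carrying a nitro group reads the same as the six-membered nitro-bearing ring. Against 2-(trifluoromethyl)phenyl the furan does separate (a 2.8-fold lower number from compound 2 to compound 4 (0.45 log units; beyond the scatter)). A clean split between nitro and trifluoromethyl groups does not hold, however: compound 3 goes against it, since it cannot be separated from the furan (a 2.0-fold lower number from compound 3 to compound 4 (0.30 log units; within the scatter)).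

Open, as far as these compounds go, is whether an amine or a carboxylic acid in place of the nitro group on the furan would move the number beyond the scatter of compound 4. No measurement here explains why these groups give these numbers.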